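From 4-chlorophenyl to 3-methoxyphenyl

This account rests on a few compounds, and the source may have more. Where it says the series, first, only, none or still open, it means among the compounds named here.

Compound 1 `Cc1ccc(-n2cc(CN3C(=O)C[C@@H]4CC[C@@]3(C)C4(C)C)nn2)cc1` gives 480 nM
Compound 2 `CC1(C)[C@H]2CC[C@]1(C)N(Cc1cn(-c3cccc(O)c3)nn1)C(=O)C2` gives 70 nM
Compound 3 `CC1(C)[C@H]2CC[C@]1(C)N(Cc1cn(-c3ccc(Cl)cc3)nn1)C(=O)C2` gives 90 nM

All three values come from a functional assay on HepG2 cells (Homo sapiens) for inhibition, read by MTT assay, with a stated time of 24 h; on this read-out higher numbers stand for weaker inhibition and lower numbers for stronger inhibition. Compound 3 stands level with compound 2, as the step shows: a 1.3-fold higher number from compound 2 to compound 3 (0.11 log units; within the scatter). It lies well under compound 1, and that gap is clearly real: a 5.3-fold lower number from compound 1 to compound 3 (0.73 log units; beyond the scatter).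

The next compound is compound 4 `COc1cccc(-n2cc(CN3C(=O)C[C@@H]4CC[C@@]3(C)C4(C)C)nn2)c1`, which has 3-methoxyphenyl in place of 4-chlorophenyl on an aromatic nitrogen. The counted difference is this: 3-methoxyphenyl in place of 4-chlorophenyl on an aromatic nitrogen.

Among the measured compounds shown here, no measured compound carries the 3-methoxyphenyl group, so the evidence is indirect. For the measured compounds named here, three steps bear on the change. Replacing 4-methylphenyl with 3-hydroxyphenyl gave a modest drop: a 6.9-fold lower number from compound 1 to compound 2 (0.84 log units; beyond the scatter). Replacing it with 4-chlorophenyl gave a similar one, and the two resulting compounds then differ by no more than the scatter. These steps show that this group can shift the number modestly, but also that two quite different groups can land together. A step beyond the scatter in this assay is therefore not expected, though a slight rise is possible, towards the value of compound 1.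

The expected step is a 1.4-fold higher number from compound 3 to compound 4 (0.16 log units; within the scatter).
For compound 4 the estimated value is 130 nM, with an expected range from 45 nM to 400 nM.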

Compound 4, half-maximal inhibitory concentration: 70 nM
For compound 4 the middle estimate is 1.9-fold (0.27 log units) above the measured one, within the range that was stated.
By their numbers in this assay, from the lowest: compounds 2, 4 and 3 (each within the scatter of the next); then compound 1.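

In this assay, 3-methoxyphenyl in place of 4-chlorophenyl on the aromatic nitrogen leaves the number level (a 1.3-fold lower number from compound 3 to compound 4 (0.11 log units; within the scatter)), so a third group now sits with the two that had already landed together. The new compound also settles a question about the oxygen: methyl in place of the hydrogen on that oxygen shows no effect (no change at the digits printed from compound 2 to compound 4 (within the scatter)), so among these compounds the hydroxyl hydrogen is not needed for the low number. Only the 4-methylphenyl compound stands apart (a 6.9-fold lower number from compound 1 to compound 4 (0.84 log units; beyond the scatter)), and since 4-chlorophenyl also sits at the 4 position yet gives a low number, the place on the phenyl ring does not by itself sort these compounds.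

The compounds shown leave open whether a plain phenyl, a 3-aminophenyl, a phenyl bearing a carboxylic acid or a longer chain such as 3-ethoxyphenyl would stay with the low group or move towards compound 1. Why 4-methylphenyl differs from the other three groups also stays unexplained, as no measurement here speaks to the cause.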